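Changing cyclohexyloxy to (oxan-4-yl)amino at the carbonyl

This account rests on a few compounds, and the source may have more. Where it says the series, first, only, none or still open, it means among the compounds named here.

Of the compounds shown here, three sharing the same carbonyl-linked core have been measured in a functional assay on Shh Light II cells (Mus musculus) for inhibition, read by a luciferase reporter; on this read-out higher numbers stand for weaker inhibition and lower numbers for stronger inhibition. Compound 2 `O=C(OC1CCCCC1)N1CCC(c2nc(-c3ccc4ccccc4n3)no2)CC1` gives 580 nM, which is the highest of the three numbers. Compound 1 `O=C(NCC1CCC1)N1CCC(c2nc(-c3ccc4ccccc4n3)no2)CC1` gives 410 nM, and compound 3 `Cn1c(-c2noc(C3CCN(C(=O)NC4CCS(=O)(=O)CC4)CC3)n2)nc2ccccc21` gives 350 nM; both of these lie within the scatter of the number for compound 2, so no order can be read among them. Going by the values given here, the one step directly comparable is a 1.4-fold higher number from compound 1 to compound 2 (0.15 log units; within the scatter), where the carbonyl carbon carries cyclohexyloxy instead of (cyclobutylmethyl)amino.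

Compound 4 `O=C(NC1CCOCC1)N1CCC(c2nc(-c3ccc4ccccc4n3)no2)CC1` has not yet been measured. It differs from compound 2 in one place: (oxan-4-yl)amino in place of cyclohexyloxy on a carbonyl carbon. This is the reverse kind of change to the step from compound 1 to compound 2, an alkoxy group giving way to an amino group on the carbonyl carbon, and that step stayed within the scatter. Compound 3, which also carries an amino group on its carbonyl, gave a number close to the other two. The expectation is therefore a step of a 1.4-fold lower number from compound 2 to compound 4 (0.14 log units; within the scatter), with no change beyond the scatter. For compound 4 the estimate in this assay is 420 nM, expected to fall between 170 nM and 1000 nM.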

Compound 4, half-maximal inhibitory concentration: 480 nM
For compound 4 the middle estimate is 1.1-fold (0.06 log units) below the measured one; measured number inside the range.
By their numbers in this assay, from the lowest: compounds 3, 1, 4 and 2 (each within the scatter of the next).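

In this assay, the exchange of cyclohexyloxy for (oxan-4-yl)amino, which adds a hydrogen-bond donor and brings a ring hetero atom, gives a 1.2-fold lower number from compound 2 to compound 4 (0.08 log units; within the scatter) and so leaves the number within the scatter. Among the amino groups, oxan-4-yl in place of cyclobutylmethyl on the amide-type nitrogen gives a 1.2-fold higher number from compound 1 to compound 4 (0.07 log units; within the scatter) and likewise stays within the scatter, so cyclohexyloxy, (cyclobutylmethyl)amino and (oxan-4-yl)amino on this carbonyl carbon cannot be told apart on this read-out. No evidence is available that bears on this result.

On these data alone, it remains open whether a group of another kind on this carbonyl carbon, such as a small primary amine, a longer alkyl chain or a chain ending in a carboxylic acid, would give a step beyond the scatter. These compounds also leave open whether the same exchange would hold up on a different core.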